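Swapping the Sulfonamide Aryl Group on a Quinoxaline Core

The source may hold more compounds than are shown below. What is called first, only, known or untested is meant among the compounds shown, and "the series" means these compounds.

Measured compounds:
compound 1 `O=[N+]([O-])c1cccc(NS(=O)(=O)c2ccc3nc(-c4ccccc4)c(-c4ccccc4)nc3c2)c1`: 85.6%
compound 2 `COc1ccccc1NS(=O)(=O)c1ccc2nc(-c3ccccc3)c(-c3ccccc3)nc2c1`: 100%

In an ADME assay on the whole organism for pharmacokinetics, with Homo sapiens as the target (on this read-out higher numbers stand for higher oral bioavailability and lower numbers for lower oral bioavailability), compound 1 gives 85.6%, the lower of the two numbers in hand. Compound 2, which carries 2-methoxyphenyl in place of 3-nitrophenyl on the sulfonamide nitrogen, gives 100% in this assay, and the step of a number 14.4 percentage points higher from compound 1 to compound 2 (beyond the scatter) lies beyond the scatter.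

Compound 3 `O=S(=O)(Nc1ccccn1)c1ccc2nc(-c3ccccc3)c(-c3ccccc3)nc2c1` has not yet been measured. Its difference from compound 1 is pyridin-2-yl in place of 3-nitrophenyl on a sulfonamide nitrogen. Within the data shown here, the only measured step that bears on this position, a number 14.4 percentage points higher from compound 1 to compound 2 (beyond the scatter), shows that replacing the 3-nitrophenyl on the sulfonamide nitrogen can raise the number by a modest amount, though the entering group here is not the same. A small rise or no change beyond the scatter is therefore expected for compound 3 in this assay, an expected step of a number 6.4 percentage points higher from compound 1 to compound 3 (within the scatter). Compound 3 is accordingly estimated at 92%, with a likely range from 76% to 100%.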

Compound 3, oral bioavailability: 100%
The estimate for compound 3 lay 8 percentage points below the measured number, within the range that was stated.
By their numbers in this assay, from the lowest: compound 1; then compounds 2 and 3 (each within the scatter of the next).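

Where the earlier pair showed one replacement of 3-nitrophenyl on the sulfonamide nitrogen, this position now shows a second with a different entering group: pyridin-2-yl, a six-membered aromatic ring with one hetero atom, gives a number 14.4 percentage points higher from compound 1 to compound 3 (beyond the scatter) in this assay. The two entering groups cannot be told apart, with no change at the digits printed from compound 2 to compound 3 (within the scatter), so a step beyond the scatter from compound 1 does not depend on one particular replacement among these compounds. Nothing measured here accounts for either step.

Only aromatic rings on that nitrogen appear among the compounds shown, so what a cyclohexyl group or a short alkyl chain there would give in this assay stays open. Also open, as far as these compounds go, is whether an unsubstituted phenyl group would stand with compound 1 or with compound 2 and compound 3.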